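The source may report more compounds than this note shows. Statements on the series, on what has been measured and on what is new or still open speak of the compounds shown alone.

Measured so far:
- compound 1, `COC(=O)C1=C(C)N=C(C)/C(=C(\O)OC)C1c1ccc(Cl)cc1`: 8130 nM
- compound 2, `COC(=O)C1=C(C)N=C(C)/C(=C(/O)OC)C1c1c(F)cccc1Cl`: 7.59 nM
- compound 3, `COC(=O)C1=C(C)N=C(C)/C(=C(\O)OC)C1c1ccccc1Cl`: 2.19 nM

In a functional assay (muscle tissue) with Cavia porcellus as the target (on this read-out lower numbers stand for an effect already at smaller amounts and higher numbers for an effect only at larger amounts of compound), compound 3 gives the lowest of the three numbers, with compound 2 the nearest and compound 1 the furthest. Compound 4, `C=Cc1ccccc1C1C(C(=O)OC)=C(C)N=C(C)/C1=C(\O)OC`, has not been measured in this assay. It differs from compound 3 by vinyl in place of chloro on an aromatic carbon. Among the measured compounds shown here, the only measured step, a 3700-fold lower number from compound 1 to compound 3 (3.57 log units; beyond the scatter), concerns where the chloro sits, not what group is carried, so no measured step bears directly on this change; it shows only that the ortho-substituted arrangement, kept in compound 4, runs with low numbers. Compound 4 is therefore expected to stay close to compound 3, at most a modest step, a 1.8-fold higher number from compound 3 to compound 4 (0.26 log units; within the scatter). Compound 4 is estimated at 4 nM, in the range 0.8 nM to 20 nM.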

Compound 4, half-maximal effective concentration: 4.47 nM
Beside the measured number, compound 4's estimate is 1.1-fold (0.05 log units) below it, and the stated range covers the measured number.
By their numbers in this assay, from the lowest: compound 3; then compounds 4 and 2 (each within the scatter of the next); then compound 1.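

In this assay, vinyl in place of chloro on the aromatic carbon ortho to a large group gives a 2.0-fold higher number from compound 3 to compound 4 (0.31 log units; beyond the scatter). The number therefore stays low without a chlorine at this position, and the 2-vinylphenyl compound keeps most of the gain over the 4-chlorophenyl compound, with a 1800-fold lower number from compound 1 to compound 4 (3.26 log units; beyond the scatter). No supporting data are available to explain either step. The compounds shown leave open how an amine, a carboxylic acid or a chain longer than vinyl would fare on this aromatic carbon.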